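The source may report more compounds than this note shows. Statements on the series, on what has been measured and on what is new or still open speak of the compounds shown alone.

Compound 1 `Nc1nc(NC2CC2)c2ncn(/C=C3/CC3(CO)CO)c2n1`: > 20000 nM
Compound 2 `CCCNc1nc(N)nc2c1ncn2/C=C1/CC1(CO)CO`: > 24000 nM
Compound 3 `CCCCCCOc1nc(N)nc2c1ncn2/C=C1/CC1(CO)CO`: > 20000 nM

All three compounds were tested in an ADME assay on Akata cells (Homo sapiens) for cytotoxicity, with a stated time of 7 days (on this read-out lower numbers stand for higher toxicity in this test and higher numbers for lower toxicity in this test), and each result is a limit of the assay and not a number. Compound 3, which carries the hexyloxy group, stands at the limit of > 20000 nM, so its exact place among the three cannot be read.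

The next compound is compound 4 `Nc1nc(SCc2ccccc2)c2ncn(/C=C3/CC3(CO)CO)c2n1`, with benzylsulfanyl in place of hexyloxy on an aromatic carbon. The closest measured changes at this carbon are a step that the two limits leave unreadable from compound 1 to compound 3 and a step that the two limits leave unreadable from compound 2 to compound 3. The remaining comparison, on the nitrogen substituent, is a step that the two limits leave unreadable from compound 1 to compound 2. Going by the values given here, none of these steps has a readable size, and none of the measured compounds carries benzylsulfanyl. They therefore offer no size or direction to carry over, and no step beyond the scatter is expected in this assay. The estimated change is a number no higher from compound 3 to compound 4 (the limit leaves the size open). For compound 4 the expected value is 20000 nM, with an estimated range from 6000 nM to 40000 nM. The result may well be reported only as a limit.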

Compound 4, half-maximal cytotoxic concentration: > 20000 nM
Compound 4: only a limit was reported (the forecaster's own chance of this, stated with the estimate: 70%); the middle value lies on the limit itself.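

Compound 4, like compounds 1, 2 and 3, gives only a limit of the assay and not a number in this assay, so none of the steps among these four compounds can be read. The compounds shown leave open whether benzylsulfanyl, hexyloxy, propylamino and cyclopropylamino on that aromatic carbon differ at all in toxicity.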